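The compounds below may be only part of what the source reports. "The series", "measured", "known", "first", "only" and "open" are said of these compounds alone.

Within the data shown here, compound 1 `Fc1cccc(-c2nc(Nc3ccccc3)c3cc(F)ccc3n2)c1` gives 45500 nM in a functional assay on U-937 cells (Homo sapiens) for cytotoxicity, read by MTT assay, with a stated time of 48 h (a higher number here means a weaker inhibitor, a lower number a stronger inhibitor), and stands at the highest of the two numbers measured so far; its nearest neighbour is compound 2 `Fc1cccc(-c2nc(Nc3ccc(Cl)cc3)c3cc(F)ccc3n2)c1`, which in this assay gives 32700 nM, and the gap a 1.4-fold lower number from compound 1 to compound 2 (0.14 log units; within the scatter) lies within the scatter. Compound 3 `Fc1cccc(-c2nc(Nc3cccc(Cl)c3)c3cc(F)ccc3n2)c1` differs from compound 1 by chloro in place of hydrogen on an aromatic carbon. Among the measured compounds shown here, the only measured step of the same kind, chloro in place of hydrogen on an aromatic carbon of the anilino ring, is a 1.4-fold lower number from compound 1 to compound 2 (0.14 log units; within the scatter), which gives no movement beyond the scatter. On that single precedent no step beyond the scatter is expected for compound 3 in this assay, at most a slight drift to a lower number. The step from compound 1 to compound 3 is therefore expected to be a 1.3-fold lower number from compound 1 to compound 3 (0.11 log units; within the scatter). Compound 3 is estimated at 35000 nM, with a range from 14000 nM to 85000 nM.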

Compound 3, half-maximal inhibitory concentration: > 50000 nM
Compound 3: no number, only a limit (the forecaster's own chance of this, stated with the estimate: 5%); middle value at least 1.4-fold (0.15 log units) away from the limit.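

In this assay compound 3 gives a limit and not a number, which is new for this series: the limit of > 50000 nM in this assay, at which 1 of the 3 values shown sits. The two steps that reach compound 3 can be read only as floors, an at least 1.0-fold higher number from compound 1 to compound 3 (0.04 log units; that floor lies within the scatter) and an at least 1.5-fold higher number from compound 2 to compound 3 (0.18 log units; that floor lies within the scatter). So the 3-chlorophenyl change, like the 4-chlorophenyl change before it, shows no step beyond the scatter, but here the true size of the step stays unbounded on the upper side, which the earlier pair of measured numbers did not allow.

From the compounds shown here alone, how far compound 3 lies past its limit stays open, and with it any real difference between the 3-chlorophenyl and 4-chlorophenyl compounds. Also open, going by these compounds, is whether an amine, a carboxylic acid or a methoxy group on the anilino ring would give a step beyond the scatter.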